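Benzamido for benzoyl at the tail of compound 1

The compounds below may be only part of what the source reports. "The series", "measured", "known", "first", "only" and "open" are said of these compounds alone.

Measured compounds in a functional assay on A549 cells (Homo sapiens) for inhibition, read by sulforhodamine B assay, with a stated time of 48 h, tested at 50 uM; a lower number here means less inhibition of growth, a higher number more inhibition of growth at the concentration tested:
- compound 1, `COc1ccc([C@@H]2C/C(=N/OCc3cn(-c4ccc(C(=O)c5ccccc5)cc4)nn3)c3cc(CC=C(C)C)c(OC)cc3O2)cc1`, gives 34%
- compound 2, `COc1cc2c(cc1CC=C(C)C)/C(=N/O)C[C@@H](c1ccc(O)cc1)O2`, gives 80%
- compound 3, `COc1cc2c(cc1CCC(C)C)C(=O)C[C@@H](c1ccc(O)cc1)O2`, gives 75%

Compound 1 stands lowest of the three numbers. Its nearest neighbour is compound 3, whose number lies higher by more than the scatter; compound 2 lies further off, also higher beyond the scatter. No pair of these compounds differs in only one place, so none of these gaps can be tied to a single structural change.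

Compound 4, `COc1ccc([C@@H]2C/C(=N/OCc3cn(-c4ccc(NC(=O)c5ccccc5)cc4)nn3)c3cc(CC=C(C)C)c(OC)cc3O2)cc1`, is not yet measured. It differs from compound 1 in one place, (benzamido in place of benzoyl on an aromatic carbon), on an aromatic carbon of a six-membered aromatic ring of carbon only, para to a large group. Going by the values given here, nothing among the measured compounds speaks to this exchange. The expected step of a number 4 percentage points higher from compound 1 to compound 4 (within the scatter) is therefore small, in either direction, and most likely not beyond the scatter. For compound 4 the estimate in this assay is 38%, with a range from 20% to 58%.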

Compound 4, percent growth inhibition at one concentration: 31%
Beside the measured number, compound 4's estimate is 7 percentage points above it, within the range that was stated.
By their numbers in this assay, from the lowest: compounds 4 and 1 (each within the scatter of the next); then compounds 3 and 2 (each within the scatter of the next).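

Benzamido in place of benzoyl, on an aromatic carbon para to a large group, gives a number 3 percentage points lower from compound 1 to compound 4 (within the scatter) in this assay and is the first step in the series that can be read at a single place. The entering group brings a nitrogen and a hydrogen-bond donor that benzoyl lacks, yet at the concentration tested this read-out does not separate the two tails. No supporting data bear on this result.

On these data alone, whether an amine or a carboxylic acid at this place would give a step beyond the scatter remains open. Also open, as far as these compounds go, is whether a longer chain between the triazole-bearing aromatic ring and the terminal phenyl ring would separate such tails in this assay at all.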